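A few compounds are considered here, and "the series" means these few. Any claim that something is new, unique, unknown or untested is made for them only; others in the source may bear on it.

Of the compounds shown here, three built on a shared core have been measured in a physicochemical assay for acid dissociation, and a fourth awaits its number. Compound 2 `CO[C@H]1C(=O)N2C(C(=O)c3ccccc3)=C(C)C(Sc3nnnn3C)S(=O)(=O)[C@H]12` is the reference point, and in this assay compound 2 gives 4.8. Compound 1 `CO[C@H]1C(=O)N2C(C(=O)C(C)(C)C)=C(C)C(Sc3nnnn3C)S(=O)(=O)[C@H]12` differs from compound 2 by tert-butyl in place of phenyl on a carbonyl carbon, and compound 1 gives 7.9, which is a number 3.10 log units higher from compound 2 to compound 1 (beyond the scatter). Compound 3 `CO[C@H]1C(=O)N2C(C(=O)c3ccccc3)=C(CSc3nnnn3C)C(Sc3nnnn3C)S(=O)(=O)[C@H]12` differs from compound 2 in another part of the molecule, and compound 3 gives 3.5, which is a number 1.30 log units lower from compound 2 to compound 3 (beyond the scatter). Among the three, compound 3 stands lowest, with compound 2 nearest to it and compound 1 furthest away.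

Compound 4 `CO[C@H]1C(=O)N2C(C(=O)C(C)(C)C)=C(CSc3nnnn3C)C(Sc3nnnn3C)S(=O)(=O)[C@H]12` has not yet been measured. It differs from compound 3 by tert-butyl in place of phenyl on a carbonyl carbon, the same change that turns compound 2 into compound 1, and it sits in the same place in both pairs, a carbonyl carbon whose other neighbour is a double-bonded ring carbon. The cores on which the change is made are not identical, though: compound 3 and compound 4 differ from compound 2 and compound 1 by (1-methyl-1H-tetrazol-5-yl)sulfanyl in place of hydrogen on a saturated chain carbon bound to a double-bonded ring carbon. For the measured compounds named here, since the change occurs twice in all, the one measured step is the only guide.

Compound 4 is expected to give 6.6, estimated to lie between 5.8 and 7.4. This estimate means a step of a number 3.10 log units higher from compound 3 to compound 4 (beyond the scatter), which rests on the same change giving a number 3.10 log units higher from compound 2 to compound 1 (beyond the scatter) when made on compound 2.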

Compound 4, acid dissociation constant: 6
Compound 4: middle estimate off by 0.60 log units, on the high side; measured number inside the range.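

In this assay, tert-butyl in place of phenyl on a carbonyl carbon gives a number 2.50 log units higher from compound 3 to compound 4 (beyond the scatter) and so moves the same way as a number 3.10 log units higher from compound 2 to compound 1 (beyond the scatter) on the other core, which shows that in these two pairs the change carries over in direction and stays large, though its size is not identical. The other change, (1-methyl-1H-tetrazol-5-yl)sulfanyl in place of hydrogen on a saturated chain carbon bound to a double-bonded ring carbon, gives a number 1.90 log units lower from compound 1 to compound 4 (beyond the scatter) when tert-butyl is present and a number 1.30 log units lower from compound 2 to compound 3 (beyond the scatter) when phenyl is present, so neither change keeps one fixed size across the set. These four compounds make up a single comparison that sets no rule for other cores, and nothing shown here explains why the sizes differ.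

The compounds shown carry only phenyl or tert-butyl on the carbonyl carbon, so it stays open how a longer chain, an amine or a carboxylic acid in that place would read in this assay and whether such a group would follow the same direction. On these data alone, the chain carbon likewise carries only hydrogen or (1-methyl-1H-tetrazol-5-yl)sulfanyl, so the size of the step with any other group there also remains open.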